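Working notes: the step from compound 3 to compound 4

The compounds below may be only part of what the source reports. "The series", "measured", "known", "first", "only" and "open" are said of these compounds alone.

Measured compounds:
Compound 1, `COc1ccc(C(=O)CSC(=S)Nc2cc(OC)c(OC)c(OC)c2)cc1`: in a functional assay on MDA-MB-231 cells (Homo sapiens) for cytotoxicity, read by MTT assay, with a stated time of 48 h (on this read-out lower numbers stand for stronger inhibition and higher numbers for weaker inhibition), compound 1 gives 16.4 ug/mL.
Compound 2, `COc1cc(-n2c(-c3ccc(Br)cc3)csc2=S)cc(OC)c1OC`: in this assay compound 2 gives 58 ug/mL.
Compound 3, `COc1cc(-n2c(-c3ccc(Cl)cc3)csc2=S)cc(OC)c1OC`: in this assay compound 3 reaches only a limit, > 100 ug/mL, which is not a number.

Compound 3 thus stands at the top end of the numbers shown, where the read-out is a limit: the limit of > 100 ug/mL in this assay, at which 1 of the 3 values shown sits. Among the measured compounds shown here, the one measured step that leads to it, an at least 1.7-fold higher number from compound 2 to compound 3 (0.23 log units; that floor lies within the scatter), has a floor inside the scatter, so it shows only that compound 3 is no stronger than compound 2 and gives no size of its own.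

Compound 4, `COc1cc(-n2c(-c3ccc(O)cc3)csc2=S)cc(OC)c1OC`, differs from compound 3 by hydroxy in place of chloro on an aromatic carbon. For the measured compounds named here, no measured step exchanges a halogen for a hydroxy group on that ring. Going by the values given here, the only step within the shared core of compounds 2, 3 and 4 is an at least 1.7-fold higher number from compound 2 to compound 3 (0.23 log units; that floor lies within the scatter), and compound 1, built on a different core, gives 16.4 ug/mL and bears nothing on this change. With compound 3 known only as a limit, no step size can be read off, and compound 4 is expected to stay close to that limit, with an at least 1.1-fold lower number from compound 3 to compound 4 (0.04 log units; that floor lies within the scatter) as the expected step. Compound 4 is estimated at 90 ug/mL, in the range 30 ug/mL to 300 ug/mL, with a real chance that only a limit is reported again.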

Compound 4, half-maximal inhibitory concentration: 22.9 ug/mL
Estimate against measurement, compound 4: 3.9-fold (0.59 log units) above, outside the stated range (below it).
By their numbers in this assay, from the lowest: compounds 1 and 4 (each within the scatter of the next); then compound 2. At a limit, above all of these: compound 3.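

In this assay, the change from 4-chlorophenyl to 4-hydroxyphenyl gives an at least 4.3-fold lower number from compound 3 to compound 4 (0.64 log units; beyond the scatter), so this position, para to a large group, responds to hydroxy in place of a halogen, which the bromo and chloro compounds alone could not show. Among the compounds shown here, that step has only a floor, and compound 3 stands at a limit rather than a number: the limit of > 100 ug/mL in this assay, at which 1 of the 4 values shown sits. The exchange of bromo for hydroxy gives the change a size between two measured numbers, with a 2.5-fold lower number from compound 2 to compound 4 (0.40 log units; beyond the scatter), whereas the only earlier step on this core, an at least 1.7-fold higher number from compound 2 to compound 3 (0.23 log units; that floor lies within the scatter), had a floor inside the scatter.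

The compounds shown leave open whether this gain is particular to hydroxy, as only bromo, chloro and hydroxy occupy this position, and an amine or a carboxylic acid in the same place would test how far it extends. For the compounds shown here, they also leave open whether the exchange would carry over to the core of compound 1, as no pair of compounds differing in one place links that core to the shared core of compounds 2, 3 and 4.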